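Urea in place of ester on the biaryl series

The source may report more compounds than this note shows. Statements on the series, on what has been measured and on what is new or still open speak of the compounds shown alone.

Compound 1 `CCCCOC(=O)c1cccc(-c2ccc(OCC)cc2)c1` carries a butoxycarbonyl group on one ring of the shared core. In an assay on COS-7 cells for inhibition of patatin-like phospholipase domain-containing protein 2 (Mus musculus) (a lower number here means a stronger inhibitor, a higher number a weaker inhibitor), compound 1 gives 100000 nM. Among the numbers shown compound 1 stands at the low end, with compound 2 `CCOc1ccc(-c2cccc(C(=O)OCC(F)(F)F)c2)cc1` nearest; in this assay compound 2 gives 120000 nM, and the step of a 1.2-fold higher number from compound 1 to compound 2 (0.08 log units; within the scatter) stays within the scatter. Compound 3 `CCOc1ccc(-c2cccc(C(=O)OCCOCCOC)c2)cc1` is reported in this assay only as a limit, > 200000 nM. That reading is the limit of > 200000 nM in this assay, at which 1 of the 3 values shown sits. The steps of an at least 2.0-fold higher number from compound 1 to compound 3 (0.30 log units; that floor lies within the scatter) and an at least 1.6-fold higher number from compound 2 to compound 3 (0.22 log units; that floor lies within the scatter) are therefore floors only, and both floors lie inside the scatter.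

Compound 4 `CCOc1ccc(-c2cccc(NC(=O)N(C)C)c2)cc1` changes compound 1 by (dimethylcarbamoyl)amino in place of butoxycarbonyl on an aromatic carbon. All three measured steps exchange the chain on the oxygen of the ester and leave the aromatic carbon untouched, so none of them bears directly on the switch from butoxycarbonyl to (dimethylcarbamoyl)amino. What the series does show is that compound 1, compound 2 and compound 3 all sit at the weak end of this assay, within the scatter of one another or at the limit. Among the measured compounds shown here, with no measured step covering this change, the number expected for compound 4 in this assay is 100000 nM, in the range 30000 nM to 300000 nM. The expected step of no change at the digits printed from compound 1 to compound 4 (within the scatter) amounts to no change beyond the scatter, and it is quite possible that this assay returns only a limit for compound 4.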

Compound 4, half-maximal inhibitory concentration: 70000 nM
The estimate for compound 4 lay 1.4-fold (0.15 log units) above the measured number; the range from low to high includes it.
By their numbers in this assay, from the lowest: compounds 4, 1 and 2 (each within the scatter of the next). At a limit, above all of these: compound 3.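

Working from the ester to the urea, (dimethylcarbamoyl)amino in place of butoxycarbonyl on an aromatic carbon is the only step shown at this position rather than on the chain of the ester, and in this assay it gives a 1.4-fold lower number from compound 1 to compound 4 (0.15 log units; within the scatter). The ester linkage can therefore be given up at this aromatic carbon, and a group with 1 hydrogen-bond donor can take the place of one with 0, without the reading leaving the scatter of compound 1; compound 4 also returns a number, 70000 nM, not a limit. Of the compounds shown, compound 3 alone stands at a limit: the limit of > 200000 nM in this assay, at which 1 of the 4 values shown sits.

A single step at this aromatic carbon cannot show whether this position can move the number beyond the scatter in either direction, and no reason for the flat reading can be drawn from it. Open questions are whether a primary amine or a carboxylic acid at this carbon, or a longer chain on the urea nitrogen in place of the methyl groups, would shift this assay beyond the scatter of compound 4.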